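Shortening the side chain of compound 1 toward a thiourea

A few compounds are considered here, and "the series" means these few. Any claim that something is new, unique, unknown or untested is made for them only; others in the source may bear on it.

Within the data shown here, compound 1, with the structure `N#CNC(=N)NCCCCCn1nc(-c2ccccc2)ccc1=O`, is the lower of the two compounds measured so far: in a functional assay on the whole organism with Rattus norvegicus as the target, at a dose of 100 mg/kg (a lower number here means less inhibition, a higher number more inhibition at the dose given (going by the name of the read-out)), compound 1 gives 31%. Among the measured compounds shown here, its only measured neighbour is compound 2, `CC/N=C(/NC#N)NCCCCn1nc(-c2ccccc2)ccc1=O`, which in this assay gives 58.8%; the change between them, a group of 8 heavy atoms in place of a group of 7 heavy atoms on the saturated chain, brought a number 27.8 percentage points higher from compound 1 to compound 2 (beyond the scatter).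

Compound 3, `CC/N=C(\S)NCCCn1nc(-c2ccccc2)ccc1=O`, is not yet measured. It differs from compound 1 as follows: a group of 6 heavy atoms (3 carbon, 2 nitrogen, 1 sulfur; no ring) in place of a group of 8 heavy atoms (4 carbon, 4 nitrogen; no ring), on a saturated chain carbon, three bonds along the chain from an aromatic nitrogen. Like the step from compound 1 to compound 2, this change sits in the side chain off the core of compound 1, and that single measured step is the only guide. For the measured compounds named here, because that step was a number 27.8 percentage points higher from compound 1 to compound 2 (beyond the scatter), a further alteration of the same chain is expected to move this assay by a modest amount, most likely upward, though the thiourea has no measured counterpart and the expectation is loose. Compound 3 is therefore estimated at 45%, in a range from 20% to 70%, a step of a number 14 percentage points higher from compound 1 to compound 3 (beyond the scatter) expected from compound 1 to compound 3.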

Compound 3, a percentage reported as inhibition, in the whole organism at one dose (the size of the read-out at that dose, not a potency): 39%
Compound 3: the middle estimate sits 6 percentage points above what was measured; low and high end bracket the measured number.
By their numbers in this assay, from the lowest: compounds 1 and 3 (each within the scatter of the next); then compound 2.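

In this assay, the group of 6 heavy atoms (3 carbon, 2 nitrogen, 1 sulfur; no ring) in place of the group of 8 heavy atoms (4 carbon, 4 nitrogen; no ring), on a saturated chain carbon, three bonds along the chain from an aromatic nitrogen, gives a number 8 percentage points higher from compound 1 to compound 3 (within the scatter). The earlier step, a number 27.8 percentage points higher from compound 1 to compound 2 (beyond the scatter), had shown that a change in this side chain can move the read-out, whereas this one shows that a sulfur-bearing group with 2 hydrogen-bond donors and 1 hydrogen-bond acceptor can enter here without a difference that stands clear of the scatter. Nothing is available to explain this result.

The compounds shown leave open how a urea, with oxygen in place of the sulfur, or a simple amine at the end of the same chain would read in this assay. They also leave open how a longer chain carrying the sulfur-bearing group would read, and how any of these compounds would behave at a dose other than the single one tested.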